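Benzyl arm substituents: expectation for compound 4

The source may hold more compounds than are shown below. What is called first, only, known or untested is meant among the compounds shown, and "the series" means these compounds.

Three analogues share one core and differ only in the group on the saturated chain carbon bound to a sulfur. Compound 1 `Cc1cc(-c2ccccc2)n(/C(N)=N/S(=O)(=O)c2cc(C)c(Cl)cc2SCc2ccccc2C)n1` in a functional assay on MCF7 cells (Homo sapiens) for cytotoxicity, read by MTT assay, with a stated time of 72 h (a higher number here means a weaker inhibitor, a lower number a stronger inhibitor), gives 80000 nM. Compound 2 `Cc1cc(-c2ccccc2)n(/C(N)=N/S(=O)(=O)c2cc(C)c(Cl)cc2SCc2ccccc2)n1` gives 15000 nM, and compound 3 `Cc1cc(-c2ccccc2)n(/C(N)=N/S(=O)(=O)c2cc(C)c(Cl)cc2SCc2cccc(C(F)(F)F)c2)n1` gives 41000 nM. Compound 3 thus stands second highest of the three numbers: its nearest neighbour is compound 1, within the scatter, and its furthest is compound 2, beyond the scatter.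

Compound 4 `Cc1ccc(CSc2cc(Cl)c(C)cc2S(=O)(=O)/N=C(\N)n2nc(C)cc2-c2ccccc2)cc1` is not yet measured. Its change from compound 3 is: 4-methylphenyl in place of 3-(trifluoromethyl)phenyl on a saturated chain carbon bound to a sulfur

Among the measured compounds shown here, two measured steps bear on this. a 2.7-fold higher number from compound 2 to compound 3 (0.44 log units; beyond the scatter) shows that trifluoromethyl in place of hydrogen on an aromatic carbon raised the number modestly. a 5.3-fold lower number from compound 1 to compound 2 (0.73 log units; beyond the scatter) shows that hydrogen in place of methyl on an aromatic carbon lowered the number modestly. a 2.0-fold lower number from compound 1 to compound 3 (0.29 log units; within the scatter) stays within the scatter, so the two substituted arms sit close together. Compound 4 carries a methyl again, so a number close to compounds 1 and 3 rather than to compound 2 is expected. For compound 4 the expected step of a 1.2-fold lower number from compound 3 to compound 4 (0.07 log units; within the scatter) stays within the scatter. Compound 4 is estimated at 35000 nM, with a range from 12000 nM to 100000 nM.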

Compound 4, half-maximal inhibitory concentration: 89000 nM
Compound 4: the middle estimate sits 2.5-fold (0.41 log units) below what was measured; measured number inside the range.
By their numbers in this assay, from the lowest: compound 2; then compounds 3, 1 and 4 (each within the scatter of the next, the first and the last beyond it).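

In this assay, the step of a 1.1-fold higher number from compound 1 to compound 4 (0.05 log units; within the scatter) lies within the scatter, so the 4-methylphenyl and 2-methylphenyl arms on the saturated chain carbon bound to a sulfur cannot be told apart, and the raised number seen with a methyl on the arm is not limited to the 2-methylphenyl compound. The step of a 5.9-fold higher number from compound 2 to compound 4 (0.77 log units; beyond the scatter) now gives a second methyl-bearing arm clearly above the unsubstituted compound 2, so all three substituted arms shown stand above compound 2, with none going against this, while the step of a 2.2-fold higher number from compound 3 to compound 4 (0.34 log units; beyond the scatter) shows that they do not form a single level, even though compound 1 lies within the scatter of both compound 3 and compound 4. Nothing shown here accounts for these differences.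

Compound 2 gives 15000 nM and the compounds shown leave open whether any group on this arm can bring the number lower still. A hydroxyl, an amine or a carboxylic acid on the phenyl ring of the arm would test whether the rise holds beyond methyl and trifluoromethyl.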